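Halogenated benzyl groups on a shared nucleoside core

The compounds below may be only part of what the source reports. "The series", "measured", "known", "first", "only" and "open" are said of these compounds alone.

Measured compounds:
compound 1, `Cc1cccc(CNc2ncnc3c2ncn3[C@@H]2O[C@H](CO)[C@@H](O)[C@H]2O)c1`: > 166000 nM
compound 2, `Cc1ccc(CNc2ncnc3c2ncn3[C@@H]2O[C@H](CO)[C@@H](O)[C@H]2O)cc1`: > 166000 nM
compound 3, `OC[C@H]1O[C@@H](n2cnc3c(NCc4c(F)ccc(F)c4F)ncnc32)[C@H](O)[C@@H]1O`: "not determined" (no result reported)

Compound 1 carries a 3-methylphenyl group on a saturated chain carbon bound to a nitrogen on an aromatic ring. In a functional assay on HOS cells (Homo sapiens) for antiproliferative activity, with a stated time of 72 h (on this read-out higher numbers stand for weaker inhibition and lower numbers for stronger inhibition), compound 1 reaches only a limit of the assay, > 166000 nM. Compound 2 also reaches only a limit, > 166000 nM. The step that the two limits leave unreadable from compound 1 to compound 2 is therefore not readable. Compound 3 stands apart: in this assay compound 3 gives "not determined" (no result reported), and the two values that exist in the set both sit at the limit of > 166000 nM in this assay, at which 2 of the 3 values shown sit.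

Compound 4, `OC[C@H]1O[C@@H](n2cnc3c(NCc4ccc(F)c(Cl)c4)ncnc32)[C@H](O)[C@@H]1O`, differs from compound 3 by 3-chloro-4-fluorophenyl in place of 2,3,6-trifluorophenyl on a saturated chain carbon bound to a nitrogen on an aromatic ring. Within the data shown here, no measured step bears on this change. The expectation for compound 4 in this assay can rest only on the weak inhibition seen throughout the set, so compound 4 is estimated at 150000 nM, within 30000 nM to 500000 nM, and quite possibly again a limit.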

Compound 4, half-maximal inhibitory concentration: > 166000 nM
Compound 4 ended at the assay's limit; the forecaster's own chance of this, stated with the estimate: 70%; middle value at least 1.1-fold (0.04 log units) away from the limit.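

Compound 1, compound 2 and compound 4 all end at a limit, so the steps among them cannot be read: the limit of > 166000 nM in this assay, at which 3 of the 4 values shown sit.

The compounds shown leave open which change on the shared core, if any, would give a readable value in this assay.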